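Lengthening the Chain on the Double-Bonded Nitrogen

The source may report more compounds than this note shows. Statements on the series, on what has been measured and on what is new or still open speak of the compounds shown alone.

Of the compounds shown here, three that share one core have been tested in a functional assay for inhibition, with Rattus norvegicus as the target; on this read-out higher numbers stand for weaker inhibition and lower numbers for stronger inhibition. Compound 1 `CCc1cc(C/N=c2\c(O)c(O)\c2=N/C(C)(C)C)ccc1C#N` gives 6100 nM in this assay. Compound 2 `CCC(C)(C)/N=c1\c(O)c(O)\c1=N/Cc1ccc(C#N)c(Cl)c1` gives 260 nM in this assay. For compound 3 `C/N=c1\c(O)c(O)\c1=N/Cc1ccc(C#N)cc1` this assay returns only a limit, > 30000 nM, and not a number. For the measured compounds named here, that is the limit of > 30000 nM in this assay, at which 1 of the 3 values shown sits, and compound 3 is the one compound of the three that sits there, so it stands at the weak end of the values shown, with no exact figure to place it.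

Compound 4 `CCC/N=c1\c(O)c(O)\c1=N/Cc1ccc(C#N)cc1` differs from compound 3 in a single place: ethyl in place of hydrogen on a saturated chain carbon bound to a double-bonded nitrogen. Going by the values given here, compound 1 and compound 2 carry larger branched groups on that same nitrogen, yet both also differ from compound 3 on the ring that bears the nitrile, so no single step between measured compounds isolates the effect of the chain on the nitrogen.

Because the starting point for compound 3 is a limit rather than a number, the size of the step to compound 4 cannot be read directly from measured pairs. Compound 4 is expected to show somewhat stronger inhibition than compound 3, a step of roughly an at least 2.0-fold lower number from compound 3 to compound 4 (0.30 log units; that floor lies within the scatter). The estimate for compound 4 in this assay is 15000 nM, with a range from 4000 nM to 60000 nM, and a real chance remains that only a limit is reported again.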

Compound 4, half-maximal inhibitory concentration: 21900 nM
Compound 4: middle estimate off by 1.5-fold (0.16 log units), on the low side; the range from low to high includes it.
By their numbers in this assay, from the lowest: compound 2; then compound 1; then compound 4. At a limit, above all of these: compound 3.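

For the compounds shown here, replacing methyl with propyl on the double-bonded nitrogen gives a measurable number in this assay, something the earlier compounds could not show for this chain while the ring bearing the nitrile stayed unchanged. Compound 3 remains at a limit in this read-out, > 30000 nM, and this is not an exact number. The only firm statement about the change is therefore a floor, an at least 1.3-fold lower number from compound 3 to compound 4 (0.13 log units; that floor lies within the scatter), so this one step neither establishes a real gain nor rules out a much larger one, and the reading rests on this: the limit of > 30000 nM in this assay, at which 1 of the 4 values shown sits.

As far as these compounds go, whether a longer chain, such as butyl or hexyl, or a cyclohexyl ring on this nitrogen would move the number further while the rest of compound 4 stays the same remains open, as does whether the trend with chain length continues at all. Compound 1 and compound 2 carry larger branched groups on the same nitrogen but also differ on the ring bearing the nitrile, so the steps that would link them to compound 4 cannot be read.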